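This account rests on a few compounds, and the source may have more. Where it says the series, first, only, none or still open, it means among the compounds named here.

Of the compounds shown here, two built on a shared core have been measured so far in a physicochemical assay for lipophilicity, at pH 7.4; a higher number here means a more lipophilic compound, a lower number a more polar compound. Compound 1 `COc1cc2c(cc1OC)[C@H](C)C(=O)N(C)C=C2` gives 3.4, and compound 2 `COCCOc1ccc2c(c1)C=CN(C)C(=O)[C@@H]2C` gives 4. Compound 2 therefore holds the higher of the two numbers, and its gap to compound 1 lies beyond the usual scatter of repeated measurements. Among the compounds with values here, no measured pair differs in only one place, so there is no direct measured step to use as a guide.

The next compound, compound 3 `C[C@H]1C(=O)N(C)C=Cc2cc(CCO)ccc21`, has not yet been measured. It differs from compound 2 at one place: 2-hydroxyethyl in place of 2-methoxyethoxy on an aromatic carbon. In words, this is 2-hydroxyethyl in place of 2-methoxyethoxy on an aromatic carbon. Without a measured precedent for this swap, the forecast rests on the structural change alone and remains uncertain. A moderate downward move in this assay, beyond the scatter, is expected. The estimated step is a number 0.90 log units lower from compound 2 to compound 3 (beyond the scatter). For compound 3 the expected value is 3.1, with an estimated range of 2.6 to 3.6.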

Compound 3, distribution coefficient: 2.6
Compound 3: the middle estimate sits 0.50 log units above what was measured; the range from low to high includes it.
By their numbers in this assay, from the lowest: compound 3; then compound 1; then compound 2.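

In this assay, within the data shown here, the swap of 2-methoxyethoxy for 2-hydroxyethyl gives the first measured change in a single place, a number 1.40 log units lower from compound 2 to compound 3 (beyond the scatter), which shows that the value responds strongly to what sits on this aromatic carbon. This one step combines several differences: the entering group has 3 heavy atoms where the leaving group has 5, 1 hydrogen-bond donor where the leaving group has 0, and 1 hydrogen-bond acceptor where the leaving group has 2, so the step alone cannot show how much each difference contributes. No measurement shown here accounts for the size of this step.

The compounds shown leave open how the value would respond to 2-methoxyethyl or 2-hydroxyethoxy on the same aromatic carbon, two groups that would help separate the effect of the terminal hydroxyl from that of the chain and its oxygen atoms. They also leave open where a group of a different kind, such as an amine or a carboxylic acid, would fall in this assay at this place.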